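Swapping the Cyclobutyl Side Chain on the Shared Core

The source may hold more compounds than are shown below. What is called first, only, known or untested is meant among the compounds shown, and "the series" means these compounds.

Measured so far:
compound 1, `N#Cc1cnc(NCc2cnccc2C(F)(F)F)cc1NC[C@H]1C[C@@H](O)C1`: 4200 nM
compound 2, `N#Cc1cnc(NCc2ccccc2C(F)(F)F)cc1N[C@H]1C[C@H](C(N)=O)C1`: > 10000 nM (a limit)
compound 3, `CC1(C)C[C@H](Nc2cc(NCc3cnccc3C(F)(F)F)ncc2C#N)CC(C)(C)[C@@H]1O`: 700 nM

In an assay on isolated protein for inhibition of protein kinase C delta type (Homo sapiens), read by TR-FRET, with a stated time of 2 h (a lower number here means a stronger inhibitor, a higher number a weaker inhibitor), compound 1 gives 4200 nM, the highest of the two plain numbers. Compound 3, the nearest neighbour, gives 700 nM, a lower number that lies beyond the scatter of repeated measurements. Compound 2 reaches only (the limit of > 10000 nM in this assay, at which 1 of the 3 values shown sits), so no number is known for it. No pair of these compounds differs in a single place, so no measured step exists.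

Compound 4, `CC1(C)[C@@H](C(N)=O)C[C@H]1Nc1cc(NCc2cnccc2C(F)(F)F)ncc1C#N`, has not been tested. Against compound 1 the change is 3-carbamoyl-2,2-dimethylcyclobutyl in place of (3-hydroxycyclobutyl)methyl on a nitrogen on an aromatic ring. The two measured neighbours point in opposite directions. Compound 3 gives 700 nM. Compound 2, by contrast, sits at a limit. Compound 4 is therefore expected at roughly 2500 nM, plausibly between 400 nM and 10000 nM, an estimated step of a 1.7-fold lower number from compound 1 to compound 4 (0.23 log units; within the scatter) that would be modest and uncertain in sign.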

Compound 4, half-maximal inhibitory concentration: 160 nM
The estimate for compound 4 lay 16-fold (1.19 log units) above the measured number; the measured number lies below the stated range.
By their numbers in this assay, from the lowest: compound 4; then compound 3; then compound 1. At a limit, above all of these: compound 2.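

In this assay, replacing (3-hydroxycyclobutyl)methyl with 3-carbamoyl-2,2-dimethylcyclobutyl on the nitrogen gives a 26-fold lower number from compound 1 to compound 4 (1.42 log units; beyond the scatter). For the compounds shown here, this is the only step here between compounds that differ in one place, so it is the first direct sign that the group on this nitrogen can strongly change the number while the rest of the molecule stays the same. The two groups share a four-membered carbon ring, so the change lies in what is attached to that ring and how it is joined to the nitrogen, and nothing shown explains the gain.

The swap changes the hydroxy group, the methylene link and the dimethyl substitution all at once, so the compounds shown cannot say which of these matters. On these data alone, how a carboxylic acid or an amine in place of the carbamoyl group would read also remains open.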